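The source may report more compounds than this note shows. Statements on the series, on what has been measured and on what is new or still open speak of the compounds shown alone.

Within the data shown here, the three measured members share one core. In a functional assay on SW480 cells (Homo sapiens) for antiproliferative activity, read by MTT assay, with a stated time of 48 h (on this read-out higher numbers stand for weaker inhibition and lower numbers for stronger inhibition), compound 1 `O=c1cc(-n2cc(CNc3ccccc3)nn2)c2cc(Br)ccc2o1` gives 18400 nM, compound 2 `O=c1cc(-n2cc(CSc3ccccc3)nn2)c2cc(Br)ccc2o1` gives 15400 nM and compound 3 `CCc1ccc(OCc2cn(-c3cc(=O)oc4ccc(Br)cc34)nn2)cc1` gives 10800 nM. Compound 3 carries the lowest of the three numbers, yet the steps reaching it, a 1.7-fold lower number from compound 1 to compound 3 (0.23 log units; within the scatter) and a 1.4-fold lower number from compound 2 to compound 3 (0.15 log units; within the scatter), are both within the scatter, as is a 1.2-fold lower number from compound 1 to compound 2 (0.08 log units; within the scatter), so the three cannot be separated. Compound 4 `COC(=O)c1ccc(OCc2cn(-c3cc(=O)oc4ccc(Br)cc34)nn2)cc1` differs from compound 3 by methoxycarbonyl in place of ethyl on an aromatic carbon. Among the measured compounds shown here, no measured step touches a group on that outer ring; the measured steps only exchange the linking atom and all stay within the scatter. Compound 4 is therefore expected to stay near compound 3, with a step of a 1.1-fold higher number from compound 3 to compound 4 (0.05 log units; within the scatter). The estimate for compound 4 in this assay is 12000 nM, range 5000 nM to 30000 nM.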

Compound 4, half-maximal inhibitory concentration: 3620 nM
Compound 4: middle estimate off by 3.3-fold (0.52 log units), on the high side; the measured number lies below the stated range.
By their numbers in this assay, from the lowest: compound 4; then compounds 3, 2 and 1 (each within the scatter of the next).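

Among these compounds, the substituent on the outer aromatic ring, para to a large group, gives the first step that lies beyond the scatter (a 3.0-fold lower number from compound 3 to compound 4 (0.47 log units; beyond the scatter)) in this assay when methoxycarbonyl replaces ethyl. This position therefore responds to substitution, whereas the linker exchanges among compound 1, compound 2 and compound 3 could not be separated. The step is modest and rests on a single pair.

On these data alone, whether a carboxylic acid, an amine or a longer chain on this carbon would give a similar number remains open. No measured property here accounts for the step.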